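The compounds below may be only part of what the source reports. "The series", "measured", "known", "first", "only" and "open" are said of these compounds alone.

The measured compounds in a functional assay on EA.hy 926 cells (Homo sapiens) for cytotoxicity, read by MTT assay, with stated times of 24 h and 12 h, tested at 12.5 uM; a lower number here means a weaker effect, a higher number a stronger effect of the compound at the concentration tested:

compound 1, `CCOC(=O)/C=C/c1cc(OC)ccc1OC(=O)c1nc(C)c(C)nc1C`, gives 15.9%.
compound 2, `Cc1nc(C)c(C(=O)Oc2ccc(/C=C/C(=O)O)cc2O)nc1C`, gives 92.8%.
compound 3, `CCOC(=O)/C=C/c1cc(Cl)ccc1OC(=O)c1nc(C)c(C)nc1C`, gives 64.9%.

Compound 1 stands at the bottom of these three numbers. Its nearest neighbour is compound 3, reached by a single change: a number 49 percentage points higher from compound 1 to compound 3 (beyond the scatter). Among the measured compounds shown here, compound 2 stands furthest from compound 1, at the top of the three, but it differs from compound 1 in more than one place, so no single step between them can be drawn; its number shows only that a compound carrying the free carboxy group can score highly here.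

The next compound, compound 4, `COc1ccc(OC(=O)c2nc(C)c(C)nc2C)c(/C=C/C(=O)O)c1`, differs from compound 1 in one place: hydrogen in place of ethyl on an oxygen next to a carbonyl group. For the measured compounds named here, the only measured single step, from compound 1 to compound 3, concerns the chloro for methoxy exchange on the aromatic ring and does not touch the ester, so it gives no direct guide to this change. Going by the values given here, the high value of compound 2, the only measured compound with a carboxy group, is the nearest hint, though weakened by its other differences. A rise beyond the scatter is therefore expected, but its size is uncertain, and the value of compound 4 is estimated at 42%, between 15% and 75%, an expected step of a number 26.1 percentage points higher from compound 1 to compound 4 (beyond the scatter).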

Compound 4, a percentage reported as activity, at one concentration (the size of the read-out at that concentration, not a potency): 21.7%
Estimate against measurement, compound 4: 20.3 percentage points above, and the stated range covers the measured number.
By their numbers in this assay, from the lowest: compounds 1 and 4 (each within the scatter of the next); then compound 3; then compound 2.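

In this assay, replacing the ethyl of the ethoxycarbonyl group with hydrogen turns it into a carboxy group and gives a number 5.8 percentage points higher from compound 1 to compound 4 (within the scatter), so this read-out does not separate the ester from the free acid at this position on the core of compound 1. Compound 4 also shows that carrying a carboxy group is not enough on its own for a high number in this small set, whereas the exchange on the aromatic ring gave a number 49 percentage points higher from compound 1 to compound 3 (beyond the scatter). No measurement is available that would explain this result.

On these data alone, it remains open whether the same exchange would also stay within the scatter on the chloro-bearing compound 3, which would show whether the result holds once the methoxy group is gone. Also open, as far as these compounds go, is whether a primary amide or a longer butyl ester at this end would move the number in this assay beyond the scatter, or whether this end of the molecule can be varied widely with little effect on the reading.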